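This account rests on a few compounds, and the source may have more. Where it says the series, first, only, none or still open, it means among the compounds named here.

The measured compounds:

compound 1 `O=C(NCCNS(=O)(=O)c1ccc(-c2ccccc2OCc2cccc(O)c2)s1)Nc1cc(C(F)(F)F)cc(C(F)(F)F)c1`, which in an ADME assay on HEK-293T cells (Homo sapiens) for cytotoxicity, read by CCK-8 assay, with a stated time of 48 h (a lower number here means a stronger inhibitor, a higher number a weaker inhibitor), gives > 20000 nM, a limit of the assay;
compound 2 `Cc1cc(C)cc(NC(=O)NCCNS(=O)(=O)c2ccc(-c3ccccc3OCc3cccc(O)c3)s2)c1`, which in this assay gives > 20000 nM, again a limit;
compound 3 `Nc1ccc(Oc2ccccc2-c2ccc(S(=O)(=O)NCCNC(=O)Nc3cc(C(F)(F)F)cc(C(F)(F)F)c3)s2)cc1`, which in this assay gives > 20000 nM, also a limit.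

None of the three is read as a number; each sits at the limit of this assay, as the limit of > 20000 nM in this assay, at which 3 of the 3 values shown sit, states. The step from compound 1 to compound 3 is a step that the two limits leave unreadable from compound 1 to compound 3, the change being (4-aminophenyl in place of 3-hydroxybenzyl on an oxygen on an aromatic ring). Because the limit of > 20000 nM in this assay, at which 3 of the 3 values shown sit, holds for both ends, this step cannot be sized from the measurements.

Compound 2 shares the same kind of sulfonamide-urea arrangement as compound 1, but the difference between the two cores is not broken down here.

Compound 4 `Cc1cc(C)cc(NC(=O)NCCNS(=O)(=O)c2ccc(-c3ccccc3Oc3ccc(N)cc3)s2)c1` is not yet measured. It stands to compound 2 as compound 3 stands to compound 1: the change is 4-aminophenyl in place of 3-hydroxybenzyl on an oxygen on an aromatic ring, the same change as from compound 1 to compound 3. Among the compounds with values here, since the earlier step is unreadable and every value so far sits at the limit, the step from compound 2 to compound 4 in this assay is expected to be a step that the limit leaves unreadable from compound 2 to compound 4, and compound 4 is expected to stay at or near the limit. The estimate for compound 4 in this assay is 25000 nM, between 12000 nM and 60000 nM, with a limit the most likely outcome.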

Compound 4, half-maximal inhibitory concentration: > 20000 nM
Compound 4 gave a limit, no number; the forecaster's own chance of this, stated with the estimate: 85%; the middle value is on the limit's open side.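

In this assay compound 4 gives > 20000 nM, a limit and not a number. The step from compound 2 to compound 4 therefore cannot be read, because both of its ends sit at a limit: the limit of > 20000 nM in this assay, at which 4 of the 4 values shown sit. The compounds shown leave open where the true value of any of the four lies, and whether 4-aminophenyl in place of 3-hydroxybenzyl changes anything in this assay.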